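The source may report more compounds than this note shows. Statements on the series, on what has been measured and on what is new or still open speak of the compounds shown alone.

In a functional assay on HepG2 cells (Homo sapiens) for cytotoxicity, read by MTT assay, with a stated time of 72 h (on this read-out lower numbers stand for stronger inhibition and higher numbers for weaker inhibition), two compounds have been measured
Compound 1 `O=C(N/N=C/c1ccc(O)cc1O)Nc1cc2c(Nc3ccc(F)c(Cl)c3)ncnc2cc1O[C@H]1CCOC1` gives 4530 nM
Compound 2 `COc1cc2ncnc(Nc3ccc(F)c(Cl)c3)c2cc1NC(=O)N/N=C/c1ccc(F)cc1` gives 31100 nM

Compound 2 stands highest of the two numbers, beyond the scatter from compound 1. Compound 3 `COc1cc2ncnc(Nc3ccc(F)c(Cl)c3)c2cc1NC(=O)N/N=C/c1cccc(Cl)c1Cl` carries 2,3-dichlorophenyl in place of 4-fluorophenyl on a carbon with a double bond to nitrogen. Within the data shown here, no measured pair shows a change of this kind, so the expectation is loose. In this assay a small step toward lower numbers is expected, not beyond the scatter (a 1.9-fold lower number from compound 2 to compound 3 (0.29 log units; within the scatter)). For compound 3 the estimated value is 16000 nM (expected range 5000 nM to 50000 nM).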

Compound 3, half-maximal inhibitory concentration: 26100 nM
The estimate for compound 3 lay 1.6-fold (0.21 log units) below the measured number; the range from low to high includes it.
By their numbers in this assay, from the lowest: compound 1; then compounds 3 and 2 (each within the scatter of the next).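

In this assay, 2,3-dichlorophenyl in place of 4-fluorophenyl on a carbon with a double bond to nitrogen gives a 1.2-fold lower number from compound 2 to compound 3 (0.08 log units; within the scatter). This position therefore takes either of these two groups without a difference that can be read, although two chlorine atoms replace one fluorine. No measurement available here accounts for this result.

Going by these compounds, whether an amine or a carboxylic acid on the phenyl group at this position would shift the number remains open. Compound 1 differs from compound 2 in more than one place, so that pair assigns no effect to any single group.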